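A few compounds are considered here, and "the series" means these few. Any claim that something is new, unique, unknown or untested is made for them only; others in the source may bear on it.

Measured compounds:
compound 1, `COc1ccc(-c2cc3ccccc3nc2/C=C/C(=O)c2ccc(F)cc2)cc1`: 820 nM
compound 2, `COc1ccc(-c2cc3ccccc3nc2/C=C/C(=O)c2ccco2)cc1`: 730 nM
compound 3, `COc1ccc(-c2cc3ccccc3nc2/C=C/C(=O)c2ccsc2)cc1`: 1220 nM

All three share one core and differ only in the group on the carbonyl carbon. In a functional assay on NCI-H1299 cells (Homo sapiens) for antiproliferative activity, read by XTT assay, with a stated time of 72 h (on this read-out lower numbers stand for stronger inhibition and higher numbers for weaker inhibition), compound 3 gives the highest of the three numbers, but the steps of a 1.5-fold higher number from compound 1 to compound 3 (0.17 log units; within the scatter) and a 1.7-fold higher number from compound 2 to compound 3 (0.22 log units; within the scatter) both fall within the scatter, as does a 1.1-fold lower number from compound 1 to compound 2 (0.05 log units; within the scatter); the three values sit together and no ordering among them can be read.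

Compound 4, `COc1ccc(-c2cc3ccccc3nc2/C=C/C(=O)c2cnc(N)nc2C)cc1`, carries 2-amino-4-methylpyrimidin-5-yl in place of thiophen-3-yl on a carbonyl carbon. Every measured exchange at this position, from 4-fluorophenyl to furan-2-yl or thiophen-3-yl, left the read-out within the scatter, so the measured steps give no sign that the group on the carbonyl carbon moves the number. Among the measured compounds shown here, the entering group is larger, six-membered and brings one hydrogen-bond donor and three acceptors, which none of the measured compounds tested; the uncertainty is therefore wider than the measured steps alone would suggest.

The step expected for compound 4 is a 1.2-fold lower number from compound 3 to compound 4 (0.09 log units; within the scatter), none beyond the scatter. Compound 4 is estimated at 1000 nM, within 300 nM to 3500 nM.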

Compound 4, half-maximal inhibitory concentration: > 10000 nM
Compound 4 was reported as a limit; the forecaster's own chance of this, stated with the estimate: 5%; at least 10-fold (1.00 log units) between middle value and limit.
By their numbers in this assay, from the lowest: compounds 2, 1 and 3 (each within the scatter of the next). At a limit, above all of these: compound 4.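

In this assay the entry for compound 4 is a limit and not a number: the limit of > 10000 nM in this assay, at which 1 of the 4 values shown sits.

This position is not indifferent to every group. Whereas 4-fluorophenyl, furan-2-yl and thiophen-3-yl sit within the scatter of one another, 2-amino-4-methylpyrimidin-5-yl gives an at least 8.1-fold higher number from compound 3 to compound 4 (0.91 log units; beyond the scatter), an at least 13-fold higher number from compound 2 to compound 4 (1.13 log units; beyond the scatter) and an at least 12-fold higher number from compound 1 to compound 4 (1.08 log units; beyond the scatter). From the compounds shown here alone, the flat picture from the first three compounds therefore holds only for those groups, and the full size of each step stays unknown past the limit.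

The entering group differs from the others in its ring size, its ring nitrogens, its amine and its methyl all at once, and the compounds shown do not separate these features. A plain pyrimidin-5-yl, or a phenyl carrying only an amine, would be the direct comparison for telling them apart.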